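The source may report more compounds than this note shows. Statements on the series, on what has been measured and on what is new or still open speak of the compounds shown alone.

Compound 1 `COc1cccc(NC(=O)COc2ccc3cc(/C=C4/SC(=O)NC4=O)ccc3c2)c1` — in an assay on isolated protein for inhibition of histone deacetylase 4 (Homo sapiens), with a stated time of 1 h (on this read-out higher numbers stand for weaker inhibition and lower numbers for stronger inhibition), compound 1 gives 1600 nM
Compound 2 `O=C(COc1ccc2cc(/C=C3/SC(=O)NC3=O)ccc2c1)Nc1ccccc1` — compound 2 gives 2100 nM
Compound 3 `Cc1cc(Br)ccc1NC(=O)COc1ccc2cc(/C=C3/SC(=O)NC3=O)ccc2c1` — compound 3 gives 550 nM

Compound 3 stands at the lowest number of the three. Its gaps to the other two are a 2.9-fold lower number from compound 1 to compound 3 (0.46 log units; beyond the scatter) and a 3.8-fold lower number from compound 2 to compound 3 (0.58 log units; beyond the scatter), both beyond the scatter. Compound 1 and compound 2 lie within the scatter of each other: a 1.3-fold higher number from compound 1 to compound 2 (0.12 log units; within the scatter).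

Compound 4 `O=C(COc1ccc2cc(/C=C3/SC(=O)NC3=O)ccc2c1)Nc1cccc(C(F)(F)F)c1` differs from compound 3 in one place: 3-(trifluoromethyl)phenyl in place of 4-bromo-2-methylphenyl on an amide-type nitrogen. Among the measured compounds shown here, no measured step makes this exact change. What bears on it are the two steps onto the 4-bromo-2-methylphenyl ring, a 2.9-fold lower number from compound 1 to compound 3 (0.46 log units; beyond the scatter) and a 3.8-fold lower number from compound 2 to compound 3 (0.58 log units; beyond the scatter): the group that leaves here is the one that gave the lowest number, while 3-methoxyphenyl in compound 1 and phenyl in compound 2 gave higher numbers. Compound 4 carries a 3-(trifluoromethyl)phenyl, as compound 1 carries a 3-methoxyphenyl, so a number between those of compound 1 and compound 3 is expected. The expected step is modest and upward: a 2.0-fold higher number from compound 3 to compound 4 (0.30 log units; within the scatter). For compound 4 the estimate is 1100 nM, with a range of 450 nM to 2700 nM.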

Compound 4, half-maximal inhibitory concentration: 2500 nM
For compound 4 the middle estimate is 2.3-fold (0.36 log units) below the measured one, within the range that was stated.
By their numbers in this assay, from the lowest: compound 3; then compounds 1, 2 and 4 (each within the scatter of the next).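

In this assay, 3-(trifluoromethyl)phenyl on the amide-type nitrogen does not keep the lower number seen with 4-bromo-2-methylphenyl (a 4.5-fold higher number from compound 3 to compound 4 (0.66 log units; beyond the scatter)). Trifluoromethyl in place of hydrogen (a 1.2-fold higher number from compound 2 to compound 4 (0.08 log units; within the scatter)) and in place of methoxy (a 1.6-fold higher number from compound 1 to compound 4 (0.19 log units; within the scatter)) both stay within the scatter, so phenyl, 3-methoxyphenyl and 3-(trifluoromethyl)phenyl do not separate here, and compound 3 alone stands apart from the other three. Nothing measured here accounts for the step from the 4-bromo-2-methylphenyl ring to the 3-(trifluoromethyl)phenyl ring.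

The bromine and the methyl of compound 3 appear only together, so the compounds shown leave open whether 4-bromophenyl or 2-methylphenyl alone would give a number like that of compound 3. They also leave open how a carboxylic acid or an amine on this ring would read in this assay.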